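Methoxy in Place of Fluoro and the Expected Edema Inhibition

The source may hold more compounds than are shown below. What is called first, only, known or untested is meant among the compounds shown, and "the series" means these compounds.

The measured compounds are:
Compound 1 `Cc1ccc(-c2nn(-c3ccc(Cl)cc3)cc2C(CC(=O)c2ccc(Cl)cc2)C(=O)c2ccc(F)cc2)cc1`, which in a functional assay on the whole organism (strain Wistar albino) for inhibition, with Rattus norvegicus as the target, read by paw edema, with stated times of 1 h and 3 h, at a dose of 0.32 mmol/kg by the intraperitoneal route (on this read-out lower numbers stand for less inhibition and higher numbers for more inhibition at the one dose given (going by the name of the read-out)), gives 19.4%.
Compound 2 `COc1ccc(C(=O)C(CC(=O)c2ccc(Cl)cc2)c2cn(-c3ccc(Cl)cc3)nc2-c2ccc(C)cc2)cc1`, which in this assay gives 23.9%.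
Compound 3 `Cc1ccc(-c2nn(-c3ccc(Cl)cc3)cc2-c2cc(-c3ccc(Cl)cc3)[nH]c2-c2ccc(F)cc2)cc1`, which in this assay gives 21%.

Compound 1 and compound 2 differ in one place only, (methoxy in place of fluoro on an aromatic carbon). This change gave a number 4.5 percentage points higher from compound 1 to compound 2 (within the scatter), so the two values are indistinguishable within the usual scatter of such measurements. Compound 3 has a different core from compound 1; the difference between the two cores is not broken down here. The values of compound 3 and compound 1 lie within the scatter of each other, as do those of compound 3 and compound 2.

The unmeasured compound 4 `COc1ccc(-c2[nH]c(-c3ccc(Cl)cc3)cc2-c2cn(-c3ccc(Cl)cc3)nc2-c2ccc(C)cc2)cc1` differs from compound 3 by methoxy in place of fluoro on an aromatic carbon. The place of the change is described in the same words for both pairs, so this is the same change as that from compound 1 to compound 2, now made on the core of compound 3. Because that earlier change produced only a number 4.5 percentage points higher from compound 1 to compound 2 (within the scatter), a step of similar small size is expected from compound 3 to compound 4, estimated as a number 4 percentage points higher from compound 3 to compound 4 (within the scatter). On that basis compound 4 is expected to give about 25% in this assay, with a likely range from 12% to 38%.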

Compound 4, a percentage reported as inhibition, in the whole organism at one dose (the size of the read-out at that dose, not a potency): 21.3%
Beside the measured number, compound 4's estimate is 3.7 percentage points above it; low and high end bracket the measured number.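

Swapping fluoro for methoxy on the core of compound 3 gave a number 0.3 percentage points higher from compound 3 to compound 4 (within the scatter) in this assay. Set beside the same swap on the core of compound 1, the two steps cannot be told apart: the same change on two cores in this assay, a number 4.5 percentage points higher (within the scatter) from compound 1 to compound 2 and a number 0.3 percentage points higher (within the scatter) from compound 3 to compound 4, 4.2 percentage points apart, within the scatter of two such steps. This shows that, on these two cores, the swap stayed within the ordinary spread of repeated measurements each time, but with both steps so small, it does not show that the swap has a real effect on either core, that fluoro and methoxy are interchangeable in general, or that the same would hold on a third core.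

The compounds shown leave open whether a different group in the same place, such as an amine or a carboxylic acid, would move the edema reading beyond the scatter. They also leave open how any of these compounds would compare at other doses, since a reading at one dose is not a measure of potency.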